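Chloro substitution on the sulfonate aryl ring of the methyl core

The source may hold more compounds than are shown below. What is called first, only, known or untested is meant among the compounds shown, and "the series" means these compounds.

Measured so far in an assay (strain Sprague-Dawley) for inhibition of Amine oxidase [flavin-containing] B (Rattus norvegicus), read by spectrophotometry, with a stated time of 5 min, tested at 10 uM; a lower number here means less inhibition, a higher number more inhibition at the concentration tested (going by the name of the read-out):
Compound 1 `CNC(=O)/C=C1/COc2cc(OS(=O)(=O)c3ccccc3)ccc21` gives 0%.
Compound 2 `CNC(=O)/C=C1/COc2cc(OS(=O)(=O)c3cccc(Cl)c3)ccc21` gives 0%.
Compound 3 `CNC(=O)/C=C1/COc2c1ccc(OS(=O)(=O)c1ccccc1)c2C` gives 5%.

Compound 3 holds the highest of the three numbers, yet its gap to compound 1, a number 5 percentage points higher from compound 1 to compound 3 (within the scatter), is within the scatter, and its value against compound 2 likewise lies within the scatter. Compound 4 `CNC(=O)/C=C1/COc2c1ccc(OS(=O)(=O)c1cccc(Cl)c1)c2C` differs from compound 3 by chloro in place of hydrogen on an aromatic carbon. For the measured compounds named here, the one measured step that bears on this is the same change made elsewhere: no change at the digits printed from compound 1 to compound 2 (within the scatter). Nothing in the measured steps points to a movement beyond the scatter, so the expected step is a number 2 percentage points lower from compound 3 to compound 4 (within the scatter), none beyond the scatter. Compound 4 is therefore estimated at 3%, with a range from -5% to 15%.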

Compound 4, a percentage reported as inhibition, at one concentration (the size of the read-out at that concentration, not a potency): 2%
Beside the measured number, compound 4's estimate is 1 percentage points above it, within the range that was stated.
By their numbers in this assay, from the lowest: compounds 1, 2, 4 and 3 (each within the scatter of the next).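

In this assay the phenyl to 3-chlorophenyl change now reads on the core of compound 3 as well, giving a number 3 percentage points lower from compound 3 to compound 4 (within the scatter) and matching its reading on the core of compound 1: (the same change on two cores in this assay, no change at the digits printed (within the scatter) from compound 1 to compound 2 and a number 3 percentage points lower (within the scatter) from compound 3 to compound 4, 3 percentage points apart, within the scatter of two such steps). The methyl change also gains a second reading, giving a number 2 percentage points higher from compound 2 to compound 4 (within the scatter) in line with the first: (the same change on two cores in this assay, a number 5 percentage points higher (within the scatter) from compound 1 to compound 3 and a number 2 percentage points higher (within the scatter) from compound 2 to compound 4, 3 percentage points apart, within the scatter of two such steps). Neither change has moved the number beyond the scatter on either background.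

As far as these compounds go, what an amine or a carboxylic acid at this aromatic carbon would do remains open, as does a longer chain in place of the methyl.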